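This account rests on a few compounds, and the source may have more. Where it says the series, first, only, none or still open, it means among the compounds named here.

Going by the values given here, in a functional assay on MCF7 cells (Homo sapiens) for inhibition, read by MTT assay, with a stated time of 72 h (on this read-out lower numbers stand for stronger inhibition and higher numbers for weaker inhibition), compound 2 `Cc1ccc(NC(=O)c2ccc(/N=N\c3c[nH]c4ccccc34)cc2)c(C)c1` gives 87000 nM, the higher of the two numbers so far; compound 1 `Cc1ccc(NC(=O)c2ccc(/N=N\c3c[nH]c4ccccc34)cc2)cc1` gives 42400 nM. Compound 3 `O=C(Nc1cccc(Cl)c1)c1ccc(/N=N\c2c[nH]c3ccccc23)cc1` differs from compound 2 by 3-chlorophenyl in place of 2,4-dimethylphenyl on an amide-type nitrogen. Among the compounds with values here, only one step bears on this: adding a methyl gave a 2.1-fold higher number from compound 1 to compound 2 (0.31 log units; beyond the scatter), so taking both methyls away is expected to move the number back the other way, while the chlorine has no measured counterpart. A step of a 2.2-fold lower number from compound 2 to compound 3 (0.34 log units; beyond the scatter) is therefore expected. Compound 3 is estimated at 40000 nM, within 15000 nM to 110000 nM.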

Compound 3, half-maximal inhibitory concentration: 82700 nM
Beside the measured number, compound 3's estimate is 2.1-fold (0.32 log units) below it, and the stated range covers the measured number.
By their numbers in this assay, from the lowest: compounds 1, 3 and 2 (each within the scatter of the next, the first and the last beyond it).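

In this assay, 3-chlorophenyl in place of 2,4-dimethylphenyl on the amide-type nitrogen gives a 1.1-fold lower number from compound 2 to compound 3 (0.02 log units; within the scatter) and 3-chlorophenyl in place of 4-methylphenyl gives a 2.0-fold higher number from compound 1 to compound 3 (0.29 log units; within the scatter). So a chlorine-bearing ring at this position cannot be told apart from either methyl-bearing ring, even though compound 1 and compound 2 themselves lie just beyond the scatter of each other. No measurement shown here accounts for this. Going by these compounds, whether an amine or a carboxylic acid on this ring would shift the number clearly remains open.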